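The compounds below may be only part of what the source reports. "The series", "measured", "known", "first", "only" and "open" are said of these compounds alone.

Measured so far in an assay on isolated protein for inhibition of Polyunsaturated fatty acid 5-lipoxygenase (Homo sapiens); a lower number here means a stronger inhibitor, a higher number a weaker inhibitor:
compound 1 `Cc1cccc(N2CCCC(=O)N2)c1`, 3400 nM
compound 2 `CCc1ccc(N2CCCC(=O)N2)cc1`, 125000 nM
compound 3 `O=C1CCCN(c2cccc(Br)c2)N1`, 1800 nM

Compound 3 gives the lowest of the three numbers in this assay; compound 1 lies within the scatter of it, compound 2 well beyond. For the measured compounds named here, the one single-place step, a 1.9-fold lower number from compound 1 to compound 3 (0.28 log units; within the scatter), is within the scatter. Compound 4 `CC(=O)c1cccc(N2CCCC(=O)N2)c1` differs from compound 3 by acetyl in place of bromo on an aromatic carbon. Going by the values given here, no measured step puts an acetyl anywhere on this core, and compound 2 differs from compound 3 in more than one place, so its value shows only that the shared core can reach a much higher number. Among the compounds with values here, with the single relevant step small, no clear direction can be claimed; compound 4 is expected near compound 3, and the expected step is a 2.8-fold higher number from compound 3 to compound 4 (0.44 log units; beyond the scatter). Compound 4 is estimated at 5000 nM, within 1200 nM to 25000 nM.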

Compound 4, half-maximal inhibitory concentration: 19000 nM
The estimate for compound 4 lay 3.8-fold (0.58 log units) below the measured number, and the stated range covers the measured number.
By their numbers in this assay, from the lowest: compounds 3 and 1 (each within the scatter of the next); then compound 4; then compound 2.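

In this assay this aromatic position proves sensitive to the group placed on it, with an 11-fold higher number from compound 3 to compound 4 (1.02 log units; beyond the scatter) and a 5.6-fold higher number from compound 1 to compound 4 (0.75 log units; beyond the scatter) as the first steps there beyond the scatter. Bromo and methyl remain indistinguishable, and acetyl gives a higher number than either. No evidence bears on what lies behind this result.

Whether the carbonyl or the additional heavy atoms of acetyl account for the change stays open. Also open, on these data alone, is how an amine, a carboxylic acid or a longer chain would read at this position.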